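The compounds below may be only part of what the source reports. "The series", "measured", "known", "first", "only" and "open" are said of these compounds alone.

Working notes on the series in a functional assay on SF-539 cells (Homo sapiens) for inhibition, read by sulforhodamine B assay, with a stated time of 48 h, tested at 10 uM; a higher number here means more inhibition at the concentration tested (going by the name of the read-out), a lower number less inhibition. Three compounds are measured. Compound 1 `Brc1cn2ccnc2c(-c2ccc3ncn(C4CCCCC4)c3c2)n1` gives 10%; compound 2 `COc1ccc(-c2cn3ccnc3c(-c3ccc4ncn(C5CCCCC5)c4c3)n2)cc1` gives -43.4%; compound 3 `Fc1ccc(-c2cn3ccnc3c(-c3ccc4ncn(C5CCCCC5)c4c3)n2)cc1` gives 17.3%. Compound 3 stands highest of the three numbers, but its gap to compound 1 is within the scatter, so only compound 2 is clearly set apart from it.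

The measured steps: a number 53.4 percentage points lower from compound 1 to compound 2 (beyond the scatter); a number 7.3 percentage points higher from compound 1 to compound 3 (within the scatter); a number 60.7 percentage points higher from compound 2 to compound 3 (beyond the scatter). Exchanging one group on the pendant phenyl ring thus moved the read-out by a large amount in one case and not at all in the other.

Compound 4 `CC(=O)c1ccc(-c2cn3ccnc3c(-c3ccc4ncn(C5CCCCC5)c4c3)n2)cc1` differs from compound 3 by acetyl in place of fluoro on an aromatic carbon. No acetyl group has been measured here. Going by the values given here, the one step at the same position, from methoxy to fluoro, was large, so a swap to acetyl may again be large, in either direction; the step from bromo to the fluorophenyl suggests the opposite. The expected step is a number 17.3 percentage points lower from compound 3 to compound 4 (beyond the scatter), with wide uncertainty. Compound 4 is estimated at 0%, within -45% to 40%.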

Compound 4, a percentage reported as inhibition, at one concentration (the size of the read-out at that concentration, not a potency): 2.82%
Estimate against measurement, compound 4: 2.8 percentage points below; the measured number falls inside the stated range.
By their numbers in this assay, from the lowest: compound 2; then compounds 4, 1 and 3 (each within the scatter of the next, the first and the last beyond it).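

In this assay, acetyl in place of fluoro gives a number 14.5 percentage points lower from compound 3 to compound 4 (beyond the scatter) and shows that two para-substituted phenyl groups can differ measurably at this position, though by far less than either differs from methoxy. Acetyl in place of methoxy gives a number 46.2 percentage points higher from compound 2 to compound 4 (beyond the scatter) and so sets compound 2 clearly apart from a second phenyl-bearing compound, while 4-acetylphenyl in place of bromo gives a number 7.2 percentage points lower from compound 1 to compound 4 (within the scatter) and leaves compound 4 unresolved from compound 1. Nothing measured here accounts for these differences.

Open, going by these compounds, is whether the low reading of compound 2 is particular to methoxy or is shared by an ethoxy group or a dimethylamino group at the same place. Also open, on these data alone, is where a carboxylic acid or a primary amide there would fall relative to compound 3 and compound 4.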